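Aryl swap next to the ring sulfur: compound 2 to 3

A few compounds are considered here, and "the series" means these few. Any claim that something is new, unique, unknown or untested is made for them only; others in the source may bear on it.

Compound 1 `CC(C)(C)Cc1c(-c2ccccn2)sc(N)c1C(=O)c1ccc(Cl)cc1` and compound 2 `CC(C)(C)Cc1c(/C=C/c2ccc(Cl)cc2)sc(N)c1C(=O)c1ccc(Cl)cc1` share one core and differ only in the group on the aromatic carbon next to the ring sulfur. In an assay on CHO cells for displacement of a labelled ligand from adenosine receptor A1 (Homo sapiens), read by scintillation counting, tested at 10 uM (a lower number here means less inhibition, a higher number more inhibition at the concentration tested (going by the name of the read-out)), compound 1 gives 1%; in this assay compound 2 gives 1%. The step of no change at the digits printed from compound 1 to compound 2 (within the scatter) shows that putting 2-(4-chlorophenyl)ethenyl in place of pyridin-2-yl left the read-out flat. Compound 2 thus stands level with compound 1 at the digits reported, both at the bottom of the scale.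

Compound 3 `COc1cccc(-c2sc(N)c(C(=O)c3ccc(Cl)cc3)c2CC(C)(C)C)c1` is the next member and is not yet measured. Its difference from compound 2: 3-methoxyphenyl in place of 2-(4-chlorophenyl)ethenyl on an aromatic carbon. Among the compounds with values here, the only measured step at this position, no change at the digits printed from compound 1 to compound 2 (within the scatter), was flat, and the two measured compounds give no sign that the group here alters the read-out. The expectation for compound 3 in this assay is therefore a step of a number 1 percentage points higher from compound 2 to compound 3 (within the scatter), nothing beyond the scatter. Compound 3 is estimated at 2%, within the range -8% to 14%.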

Compound 3, a percentage reported as inhibition, at one concentration (the size of the read-out at that concentration, not a potency): 1%
Compound 3: the middle estimate sits 1 percentage points above what was measured; the range from low to high includes it.
By their numbers in this assay, from the lowest: compounds 1, 2 and 3 (each within the scatter of the next).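

In this assay, 3-methoxyphenyl on this aromatic carbon gives no change at the digits printed from compound 2 to compound 3 (within the scatter), and measured against pyridin-2-yl it gives no change at the digits printed from compound 1 to compound 3 (within the scatter). The flat result now covers three groups rather than two: a carbon-only aromatic ring bearing a methoxy group behaves here like the pyridine ring and the ring carried on a double bond, and none of the three compounds goes against this. No supporting data bear on why the read-out stays flat.

As far as these compounds go, all three compounds sit at the bottom of the scale, so it remains open whether these groups would differ on a core that shows real inhibition. Also open, from the compounds shown here alone, is whether an amine, a carboxylic acid or a longer alkyl chain on this carbon, or another group in place of neopentyl, would move the read-out at all.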